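Compound 2 and a ring exchange on an aromatic carbon

This account rests on a few compounds, and the source may have more. Where it says the series, first, only, none or still open, it means among the compounds named here.

Compound 1 `CN(C[C@H]1Cc2c(cccc2N2CCC(N)CC2)CN1)[C@H]1CCCc2cccnc21`: 70.3%
Compound 2 `CN(C)C1CCN(c2cccc3c2C[C@H](CN(C)[C@H]2CCCc4cccnc42)NC3)CC1`: 70.2%

In an ADME assay on microsomes from liver (Mus musculus) for metabolic stability, using NADPH, with a stated time of 10 min (on this read-out higher numbers stand for a more stable compound and lower numbers for a less stable compound), compound 2 stands at 70.2%, within the scatter of compound 1. Compound 3 `CN1CC[C@H]2CN(c3cccc4c3C[C@H](CN(C)[C@H]3CCCc5cccnc53)NC4)C[C@H]21` differs from compound 2 by a group of 9 heavy atoms (7 carbon, 2 nitrogen; 2 five-membered non-aromatic rings with 1 hetero atom each) in place of a group of 9 heavy atoms (7 carbon, 2 nitrogen; one six-membered non-aromatic ring with 1 hetero atom), on an aromatic carbon. Among the compounds with values here, the one measured step, a number 0.1 percentage points lower from compound 1 to compound 2 (within the scatter), bears on this only loosely, since it concerns dimethylamino in place of amino on a saturated ring carbon. No measured step covers the exchange of rings, so the data give no reason to expect a shift beyond the scatter. The expected step is a number 4.2 percentage points lower from compound 2 to compound 3 (within the scatter). Compound 3 is estimated at 66%, with an expected range from 50% to 82%.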

Compound 3, percent of the compound remaining: 24%
Compound 3: middle estimate off by 42 percentage points, on the high side; measured number outside the range, below it.
By their numbers in this assay, from the lowest: compound 3; then compounds 2 and 1 (each within the scatter of the next).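

In this assay the aromatic carbon proves sensitive to the ring system it carries, with a number 46.2 percentage points lower from compound 2 to compound 3 (beyond the scatter) and a number 46.3 percentage points lower from compound 1 to compound 3 (beyond the scatter) even though the 4-(dimethylamino)piperidin-1-yl group and the group with two five-membered rings have the same heavy-atom count. The earlier pair had shown only that amino and dimethylamino on the saturated ring carbon gave values within the scatter. Nothing available explains the fall. Going by these compounds, whether the loss follows from the fused pair of five-membered rings, its stereocentres or its nitrogen placement stays open, as does how a morpholine or an open-chain dimethylaminoethyl amine would behave on this aromatic carbon.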